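The source may hold more compounds than are shown below. What is called first, only, known or untested is meant among the compounds shown, and "the series" means these compounds.

Measured compounds:
compound 1, `COc1ccccc1C(=O)Nc1nnc(SCC(=O)Nc2ccc(Cl)cn2)s1`: > 80000 nM
compound 2, `O=C(CSc1nnc(NC(=O)CCl)s1)Nc1ccc(Cl)cn1`: 5700 nM
compound 3, `O=C(CSc1nnc(NC(=O)CCl)s1)Nc1ccc(Br)cn1`: 7500 nM

The assay throughout is a functional assay on NCI-H460 cells (Homo sapiens) for antiproliferative activity, read by MTT assay, with a stated time of 48 h; on this read-out lower numbers stand for stronger inhibition and higher numbers for weaker inhibition. For compound 1 the value is a limit of the assay, not a number; the same limit is the one described by the limit of > 80000 nM in this assay, at which 1 of the 3 values shown sits. Among the two real numbers, compound 3 and compound 2 sit within the scatter of each other, as a 1.3-fold higher number from compound 2 to compound 3 (0.12 log units; within the scatter) shows, and the third value is the limit just named. Compound 4 is `O=C(CSc1nnc(NC(=O)CCCl)s1)Nc1ccc(Br)cn1`; it differs from compound 3 by chloromethyl in place of chloro on a saturated chain carbon bound to a carbonyl carbon.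

For the measured compounds named here, two measured steps bear on this. The change of the acyl group in an at least 14-fold lower number from compound 1 to compound 2 (1.14 log units; beyond the scatter) was large, which shows that this part of the molecule can move the number strongly. The halogen swap in a 1.3-fold higher number from compound 2 to compound 3 (0.12 log units; within the scatter) stayed within the scatter. Going by the values given here, no measured step extends the chain on the chloroacetyl side, so the size of the step to compound 4 rests on the acyl group being a sensitive position. Compound 4 is therefore expected to give a somewhat higher number than compound 3, estimated at a 2.1-fold higher number from compound 3 to compound 4 (0.33 log units; beyond the scatter). The estimate for compound 4 is 16000 nM, with a range from 5000 nM to 60000 nM.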

Compound 4, half-maximal inhibitory concentration: 560 nM
Beside the measured number, compound 4's estimate is 29-fold (1.46 log units) above it, outside the stated range (below it).
By their numbers in this assay, from the lowest: compound 4; then compounds 2 and 3 (each within the scatter of the next). At a limit, above all of these: compound 1.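

In this assay, the acyl side of the molecule responds not only to the exchange of a whole group but also to a small change within the chain: going from chloromethyl to 2-chloroethyl gives a 13-fold lower number from compound 3 to compound 4 (1.13 log units; beyond the scatter). The earlier change at this position exchanged 2-methoxyphenyl for chloromethyl and so altered the whole acyl group, whereas compound 3 and compound 4 both keep a chlorine on this chain, which shows that the chlorine alone does not set the number and that the chain carrying it matters as well. Nothing measured here gives a reason for the size of this step.

The compounds shown leave open whether the step holds with chloro rather than bromo on the aromatic carbon, where the halogen swap itself stayed within the scatter. They also leave open how far the trend runs along the chain, since a longer chain ending in chlorine, or an amine or a hydroxyl group in place of the chlorine of the 2-chloroethyl group, would test whether the chain length or the chlorine carries the effect.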